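The compounds below may be only part of what the source reports. "The series", "measured", "known", "first", "only" and "open" are said of these compounds alone.

Measured compounds:
- compound 1 `C=C1[C@@H](OC(C)=O)C[C@@H]2[C@](C)(CO[Si](C)(C)C(C)(C)C)[C@H](OC(C)=O)CC[C@@]2(C)[C@@H]1C[C@@H](Nc1ccccc1F)C1=CCOC1=O`: 2930 nM
- compound 2 `C=C1CC[C@@H]2[C@](C)(CO[Si](C)(C)C(C)(C)C)[C@H](OC(C)=O)CC[C@@]2(C)[C@@H]1C/C=C1/C(=O)OC[C@H]1OC(C)=O`: 4840 nM
- compound 3 `C=C1[C@@H](OC(C)=O)C[C@@H]2[C@](C)(COC=O)[C@H](OC(C)=O)CC[C@@]2(C)[C@@H]1C[C@@H](Nc1ccc(C(=O)O)cc1)C1=CCOC1=O`: 41700 nM

All three were tested in a functional assay on MCF7 cells (Homo sapiens) for cytotoxicity, read by sulforhodamine B assay; on this read-out lower numbers stand for stronger inhibition and higher numbers for weaker inhibition. Compound 1 has the lowest number of the three. Compound 2 sits close to it, within the usual scatter, so the two cannot be told apart. Compound 3, with its value of 41700 nM, lies well beyond the scatter above compound 1, and is the only one of the three that clearly differs from it.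

Compound 4 `C=C1[C@@H](OC(C)=O)C[C@@H]2[C@](C)(CO[Si](C)(C)C(C)(C)C)[C@H](OC(C)=O)CC[C@@]2(C)[C@@H]1C[C@@H](Nc1ccc(F)cc1)C1=CCOC1=O` is built from compound 1 by a single change: 4-fluorophenyl in place of 2-fluorophenyl on an amine nitrogen. The same atoms are kept and only joined differently, so nothing is added or removed; the fluorine is simply placed elsewhere on the aromatic ring that sits on the amine nitrogen.

Among the measured compounds shown here, no measured pair in this set shows what such a move does, so the expectation rests on the small size of the change. The step of a 1.0-fold higher number from compound 1 to compound 4 (0.01 log units; within the scatter) is estimated to be small, in no clear direction, and not beyond the scatter. Compound 4 is therefore expected to give about 3000 nM in this assay, with a range from 1200 nM to 8000 nM.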

Compound 4, half-maximal inhibitory concentration: 4340 nM
Compound 4: the middle estimate sits 1.4-fold (0.16 log units) below what was measured; measured number inside the range.
By their numbers in this assay, from the lowest: compounds 1, 4 and 2 (each within the scatter of the next); then compound 3.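

In this assay, among the compounds shown here, the pair gives the first clean reading in this set, since only the place of the fluorine on the aromatic ring changes, and the result is a 1.5-fold higher number from compound 1 to compound 4 (0.17 log units; within the scatter) with the rest of the molecule held constant. For these two placements, then, 2-fluorophenyl and 4-fluorophenyl on the amine nitrogen cannot be told apart on this read-out, which means that moving the fluorine between them has no effect that this cytotoxicity measurement can resolve. The pair gives the size of the step and nothing more, and no separate measurement is available that could explain it.

From the compounds shown here alone, whether a plain phenyl on the amine nitrogen, or a chlorine or a methoxy group on that ring in place of the fluorine, would give a number beyond the scatter remains open. Going by these compounds, compound 3 carries a carboxylic acid on its ring but differs from compound 1 in more than one place, so what that acid does on its own also remains open.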